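A few compounds are considered here, and "the series" means these few. Any claim that something is new, unique, unknown or untested is made for them only; others in the source may bear on it.

In a functional assay on MDA-MB-231 cells (Homo sapiens) for inhibition, read by MTT assay, with stated times of 18 h and 4 h (a lower number here means a stronger inhibitor, a higher number a weaker inhibitor), compound 3 `CCCCCCCCCCOP(=O)(O)OCCSC(=S)N1CCCCCC1` gives 11400 nM, and compound 2 `CCCCCCCCOP(=O)(O)OCCSC(=S)N1CCCC1` gives 69000 nM. The gap between these two numbers lies beyond the scatter, which puts compound 3 lowest of the measured numbers. Compound 1 `CCCCCCCCCCCCCCCCOP(=O)(O)OCCSC(=S)N1CCCCCC1` reaches only a limit of the assay, > 100000 nM.

Compound 4 `CCCCCCCCCCOP(=O)(O)OCCSC(=S)N1CCCC1` differs from compound 3 by one change, pyrrolidin-1-yl in place of azepan-1-yl on a thiocarbonyl carbon. Within the data shown here, the only measured step, an at least 8.7-fold lower number from compound 1 to compound 3 (0.94 log units; beyond the scatter), alters the chain and leaves azepan-1-yl in place, so it says nothing directly about this ring swap. The closest guide is compound 2, which carries pyrrolidin-1-yl on a different chain and gives 69000 nM. That value points to a modest rise in this assay, perhaps not beyond the scatter.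

The expected change is a 1.8-fold higher number from compound 3 to compound 4 (0.24 log units; within the scatter). For compound 4 the estimated value is 20000 nM, with an expected range from 7000 nM to 60000 nM.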

Compound 4, half-maximal inhibitory concentration: 67000 nM
For compound 4 the middle estimate is 3.4-fold (0.53 log units) below the measured one; the whole stated range lies below it.
By their numbers in this assay, from the lowest: compound 3; then compounds 4 and 2 (each within the scatter of the next). At a limit, above all of these: compound 1.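

In this assay, the ring on the thiocarbonyl carbon clearly matters: with the chain unchanged, pyrrolidin-1-yl in place of azepan-1-yl gives a 5.9-fold higher number from compound 3 to compound 4 (0.77 log units; beyond the scatter) and so weakens inhibition. Among these compounds, the earlier step changed only the chain, so this is the first direct look at the ring alone. Between the two pyrrolidin-1-yl compounds, the chain step gives a 1.0-fold lower number from compound 2 to compound 4 (0.01 log units; within the scatter) in this assay, so ethyl in place of hydrogen at that chain carbon makes no difference that can be read here.

On these data alone, how a piperidin-1-yl or morpholin-4-yl group would behave on the same thiocarbonyl carbon remains open. Nothing shown here gives a reason for the effect of the ring swap.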